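Sulfonamide aryl swap: methoxy for isopropyl

The source may report more compounds than this note shows. Statements on the series, on what has been measured and on what is new or still open speak of the compounds shown alone.

Measured so far:
compound 1 `CC(C)c1ccc(S(=O)(=O)NCCCCCCNCc2ccc(Br)cc2)cc1` — 5730 nM
compound 2 `O=S(=O)(NCCCCCCNCc1ccc(Br)cc1)c1cc(C(F)(F)F)cc(C(F)(F)F)c1` — 2970 nM

In a functional assay on MIA PaCa-2 cells (Homo sapiens) for inhibition, read by MTT assay, with a stated time of 72 h (a higher number here means a weaker inhibitor of growth, a lower number a stronger inhibitor of growth), compound 1 gives 5730 nM and compound 2 gives 2970 nM; the two numbers sit within the scatter of each other, so nothing separates them on the evidence in hand. Going by the values given here, no step between measured compounds bears on the change now at issue.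

Compound 3 `COc1ccc(S(=O)(=O)NCCCCCCNCc2ccc(Br)cc2)cc1` differs from compound 1 by methoxy in place of isopropyl on an aromatic carbon. Among the compounds with values here, with no comparable step to lean on, the step of a 1.0-fold higher number from compound 1 to compound 3 (0.02 log units; within the scatter) in this assay is expected to be small, none beyond the scatter in either direction. Compound 3 is therefore estimated at 6000 nM, with a range of 2500 nM to 15000 nM.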

Compound 3, concentration for 50% growth inhibition: 13000 nM
Compound 3: the middle estimate sits 2.2-fold (0.34 log units) below what was measured; the measured number falls inside the stated range.
By their numbers in this assay, from the lowest: compounds 2 and 1 (each within the scatter of the next); then compound 3.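

In this assay, going by these compounds alone, methoxy in place of isopropyl gives a 2.3-fold higher number from compound 1 to compound 3 (0.36 log units; beyond the scatter), the first single-place change and one beyond the scatter. Growth inhibition therefore responds to the group on this aromatic carbon, and the 4-isopropylphenyl to 4-methoxyphenyl change is not neutral here. Within the data shown here, nothing measured so far offers an explanation for this step.

Still open, on these data alone, is how an amine, a hydroxyl or a tert-butyl group on this carbon would compare with isopropyl and methoxy. Also open, as far as these compounds go, is whether a longer chain on the shared core would preserve this step.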